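Swapping a Fluorobenzyl for an Acetoxyethyl Tail

The compounds below may be only part of what the source reports. "The series", "measured", "known", "first", "only" and "open" are said of these compounds alone.

Three measured analogs share one core. Compound 1 `CCCCC(C(=O)OC)N1C(=O)/C(=C/c2ccc(C(=O)N[C@@H](CCCNC(=N)N)C(=O)N[C@@H](CCCCN)C(=O)N[C@@H](CCCC)C(N)=O)cc2)SC1=S` gives 0.87 10^-6 cm/s in an ADME assay for permeability, using PAMPA; on this read-out lower numbers stand for lower permeability and higher numbers for higher permeability. Compound 2 `CCCC[C@H](NC(=O)[C@H](CCCCN)NC(=O)[C@H](CCCNC(=N)N)NC(=O)c1ccc(/C=C2\SC(=O)N(Cc3ccc(F)cc3)C2=O)cc1)C(N)=O` gives 0.43 10^-6 cm/s in this assay, and compound 3 `CCCC[C@H](NC(=O)[C@H](CCCCN)NC(=O)[C@H](CCCNC(=N)N)NC(=O)c1ccc(/C=C2\SC(=S)N(Cc3ccc(OC)cc3)C2=O)cc1)C(N)=O` gives 0.6 10^-6 cm/s. Among the measured compounds shown here, the only step between compounds differing in one place, a 1.5-fold lower number from compound 1 to compound 3 (0.16 log units; within the scatter), exchanges one group on the amide-type nitrogen in the ring for another and does not leave the scatter. Compound 2 gives the smallest of the three numbers, yet its gap to compound 3 stays within the scatter; only its gap to compound 1 reaches beyond it.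

Compound 4 `CCCC[C@H](NC(=O)[C@H](CCCCN)NC(=O)[C@H](CCCNC(=N)N)NC(=O)c1ccc(/C=C2\SC(=O)N(CCOC(C)=O)C2=O)cc1)C(N)=O` has not yet been measured. It differs from compound 2 by acetoxymethyl in place of 4-fluorophenyl on a saturated chain carbon bound to an amide-type nitrogen in a ring. For the measured compounds named here, no measured step covers an acetoxymethyl or a 2-acetoxyethyl group, so the comparison rests on the close spread of the three known numbers and on the single measured exchange at this position, which moved nothing beyond the scatter. The step of a 1.2-fold higher number from compound 2 to compound 4 (0.07 log units; within the scatter) is therefore expected to stay within the scatter. Compound 4 is estimated at 0.5 10^-6 cm/s, with a range from 0.25 10^-6 cm/s to 1 10^-6 cm/s.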

Compound 4, apparent permeability: "impermeable" (no number reported)
For compound 4 the study gives words and no number; no gap can be computed for the estimate.
By their numbers in this assay, from the lowest: compounds 2, 3 and 1 (each within the scatter of the next, the first and the last beyond it).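

In this assay, among the compounds shown here, compound 4 is reported only in words, as "impermeable", so no step from compound 2 to compound 4 can be read. Nothing shown bears on this result. The compounds shown leave open where compound 4 stands numerically against compounds 1, 2 and 3.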